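Dropping a Chlorine from an Aryl Piperazine Dithiocarbamate

A few compounds are considered here, and "the series" means these few. Any claim that something is new, unique, unknown or untested is made for them only; others in the source may bear on it.

Measured compounds, in a functional assay on A-375 cells (Homo sapiens) for antiproliferative activity, read by CCK-8 assay, with a stated time of 72 h, tested at 2 uM; on this read-out higher numbers stand for a stronger effect at the one concentration tested and lower numbers for a weaker effect:
Compound 1, `Nc1ccccc1NC(=O)c1ccc(CSC(=S)N2CCN(c3ccc(Cl)cc3)CC2)cc1`: 32.2%
Compound 2, `CCN(Cc1ccncc1)C(=S)SCc1ccc(C(=O)Nc2ccccc2N)cc1`: 67.2%
Compound 3, `COC(=O)c1ccc2c(c1)CCN2C(=S)SCc1ccc(C(=O)Nc2ccccc2N)cc1`: 37.5%

All three share a core built around a benzamide bearing an aminophenyl group, joined through a sulfur-bound linker to a dithiocarbamate whose nitrogen belongs to a different amine in each case. In this assay compound 1 stands at the low end of the three numbers. The value of compound 3 is within the usual scatter of it, so no order between these two can be read; compound 2, with its open-chain amine, lies well beyond the scatter above both.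

Compound 4, `Nc1ccccc1NC(=O)c1ccc(CSC(=S)N2CCN(c3ccccc3)CC2)cc1`, keeps the whole of compound 1 except at one spot: hydrogen in place of chloro on an aromatic carbon. Put another way, the 4-chlorophenyl becomes a plain phenyl. No measured pair here changes only at this spot, so nothing shown tells how much such a swap moves the read-out. A single chlorine at the edge of the molecule is a small change, and the expected step of a number 2.2 percentage points lower from compound 1 to compound 4 (within the scatter) is therefore estimated as none beyond the scatter. Compound 4 is expected to give about 30%, most likely between 15% and 48%.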

Compound 4, a percentage reported as inhibition, at one concentration (the size of the read-out at that concentration, not a potency): 27.5%
The estimate for compound 4 lay 2.5 percentage points above the measured number, within the range that was stated.
By their numbers in this assay, from the lowest: compounds 4, 1 and 3 (each within the scatter of the next); then compound 2.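

In this assay, going from the 4-chlorophenyl to a plain phenyl gives a number 4.7 percentage points lower from compound 1 to compound 4 (within the scatter), so at this aromatic carbon the two compounds cannot be told apart. Among the compounds shown here, this is the first pair that differs in one place only, and it shows that the chlorine, the one heavy atom that leaves, is not needed for compound 4 to give a number that reads alike with that of compound 1 at the single concentration tested. Nothing available here speaks to why chloro and hydrogen read alike at this spot.

So far only chloro and hydrogen can be compared at this carbon, so it stays open whether a larger or very different group, such as methoxy, an amine or a carboxylic acid, would move the number beyond the scatter. Each compound also has a reading at one concentration only, which leaves open whether compound 1 and compound 4 would still read alike at other concentrations, or whether the same swap would matter on a different amine part of the dithiocarbamate.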